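Chlorophenyl placement in a small hydrazine-ring series

This account rests on a few compounds, and the source may have more. Where it says the series, first, only, none or still open, it means among the compounds named here.

Of the compounds shown here, three have been measured in an assay on HEK293 cells for inhibition of protein kinase C zeta type (Homo sapiens), read by 33P incorporation, with a stated time of 40 min, tested at 20 uM, in the presence of a further agent that is not named here; a higher number here means more inhibition at the concentration tested (going by the name of the read-out), a lower number less inhibition. Compound 1 `COc1ccc(C2=NN(c3ccc(Cl)cc3)C(c3ccc(Cl)cc3)C2)cc1` gives 23%. Compound 2 `COc1ccc(C2=NN(c3ccc(Cl)cc3)C(c3cccc(Cl)c3)C2)cc1` gives 39%. Compound 3 `Oc1ccc(C2=NN(c3cccc(Cl)c3)C(c3cccc(Cl)c3)C2)cc1` gives 85.7%, the highest number of the three, with the gaps down to compound 2 and to compound 1 both beyond the scatter.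

Between compound 2 and compound 1 the structural change is 4-chlorophenyl in place of 3-chlorophenyl on a saturated ring carbon, and it produced a number 16 percentage points lower from compound 2 to compound 1 (beyond the scatter). How the core of compound 3 differs from that of compound 2 is not broken down here.

Compound 4 `Oc1ccc(C2=NN(c3cccc(Cl)c3)C(c3ccc(Cl)cc3)C2)cc1` is still to be measured in this assay. It differs from compound 3 by 4-chlorophenyl in place of 3-chlorophenyl on a saturated ring carbon. Among the measured compounds shown here, this is the same kind of change as the one from compound 2 to compound 1, not the same: in compound 3 the changed carbon sits next to the ring atom that bears a 3-chlorophenyl group and two ring bonds from the ring atom that bears a 4-hydroxyphenyl group, whereas in compound 2 the neighbouring ring atom bears a 4-chlorophenyl group and the atom two ring bonds away bears a 4-methoxyphenyl group.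

For the measured compounds named here, the expectation for compound 4 is a step of a number 17.7 percentage points lower from compound 3 to compound 4 (beyond the scatter), resting on the modest drop seen as a number 16 percentage points lower from compound 2 to compound 1 (beyond the scatter) when the same kind of change was made, with the caveat that only that one precedent exists and its surroundings differ. Compound 4 is therefore estimated at 68%, within 50% to 86%.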

Compound 4, a percentage reported as inhibition, at one concentration (the size of the read-out at that concentration, not a potency): 86.2%
Compound 4: the middle estimate sits 18.2 percentage points below what was measured; measured number above the stated range.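

In this assay, 4-chlorophenyl in place of 3-chlorophenyl on a saturated ring carbon gives a number 0.5 percentage points higher from compound 3 to compound 4 (within the scatter), so the drop seen on the other core does not recur here. The effect of this change therefore differs between the two cores and cannot simply be carried from one to the other in this series: the same change on two cores in this assay, a number 16 percentage points lower (beyond the scatter) from compound 2 to compound 1 and a number 0.5 percentage points higher (within the scatter) from compound 3 to compound 4, 16.5 percentage points apart, beyond the scatter of two such steps This does not show which core difference matters, as the two cores differ both in 4-hydroxyphenyl against 4-methoxyphenyl and in the chlorophenyl group on the neighbouring ring atom, and two pairs give no general rule for other cores.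

The compounds shown leave open how each of those two core differences acts alone, which would take pairs that differ only in the 4-hydroxyphenyl or 4-methoxyphenyl group, or only in the chlorophenyl group on that ring atom. Also open, from the compounds shown here alone, is how the series reads with a carboxylic acid, an amine or a longer alkoxy chain on that phenyl ring in place of the hydroxy group, and, as each number here comes from one concentration, how the compounds rank in potency.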